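The source may hold more compounds than are shown below. What is called first, only, known or untested is meant among the compounds shown, and "the series" means these compounds.

Of the compounds shown here, three with a shared core have been measured in an assay on HEK293 cells for agonist activity at transient receptor potential cation channel subfamily M member 8 (Homo sapiens), read by fluorescence and calcium flux, with a stated time of 15 min; on this read-out higher numbers stand for an effect only at larger amounts of compound and lower numbers for an effect already at smaller amounts. Compound 1 `CCN(Cc1cccs1)C(=O)COc1ccccc1` gives 1400 nM, compound 2 `CON(Cc1cccs1)C(=O)COc1ccc(C)cc1` gives 10 nM, and compound 3 `Cc1ccc(OCC(=O)N(C)Cc2cccs2)cc1` gives 400 nM. Compound 3 therefore stands second highest of the three numbers: compound 1 lies above it, whereas the step of a 40-fold higher number from compound 2 to compound 3 (1.60 log units; beyond the scatter) is large and well beyond the scatter. That step changed only the group on the amide-type nitrogen, methyl in place of methoxy, and shows how strongly this one position can move the read-out.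

Compound 4 `Cc1ccc(OCC(=O)N(Cc2cccs2)c2ncccn2)cc1` has not been measured. It differs from compound 3 in a single place: pyrimidin-2-yl in place of methyl on an amide-type nitrogen. For the measured compounds named here, the only measured change at this nitrogen is the methoxy-to-methyl step just described; no measured compound carries an aromatic ring there, so the direction of the new change cannot be read from the data. Given that the position is sensitive, a step of a 1.8-fold higher number from compound 3 to compound 4 (0.24 log units; within the scatter) is expected as a central guess, with wide uncertainty. Compound 4 is estimated at 700 nM, within a range of 100 nM to 5000 nM.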

Compound 4, half-maximal effective concentration: 3700 nM
Compound 4: middle estimate off by 5.3-fold (0.72 log units), on the low side, and the stated range covers the measured number.
By their numbers in this assay, from the lowest: compound 2; then compound 3; then compound 1; then compound 4.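

Putting pyrimidin-2-yl on the amide-type nitrogen gives a 9.3-fold higher number from compound 3 to compound 4 (0.97 log units; beyond the scatter) in this assay, so a six-membered aromatic ring at this place goes with a higher number than methyl, not a lower one. Against methoxy, the same ring gives a 370-fold higher number from compound 2 to compound 4 (2.57 log units; beyond the scatter), the largest step at this nitrogen so far, and the three groups now run in one order: methoxy lowest, then methyl, then pyrimidin-2-yl. Nothing available explains this order.

The compounds shown leave open whether the higher number goes with the ring as such or with its nitrogen atoms, which a plain phenyl ring on the same nitrogen could help to separate. They also leave open how an ethoxy group or a longer chain such as propyl would compare at this place.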